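This account rests on a few compounds, and the source may have more. Where it says the series, first, only, none or still open, it means among the compounds named here.

Measured so far in a functional assay on CHO cells for agonist activity at Alpha-1D adrenergic receptor (Homo sapiens), read by FLIPR and calcium flux; a lower number here means that less compound is needed, a higher number that more compound is needed for the effect:

Compound 1 `COc1cccc(C2CCc3nc[nH]c3C2)c1`: > 10000 nM
Compound 2 `Clc1ccccc1C1CCc2nc[nH]c2C1`: > 10000 nM
Compound 3 `Clc1cccc(C2CCc3nc[nH]c3C2)c1`: > 10000 nM

Each of these values is a limit of this assay, not a number. For compound 3 the value > 10000 nM is such a limit. For compound 1 the value > 10000 nM is likewise a limit. For compound 2 the value > 10000 nM is a limit as well. Compound 3 and compound 1 differ by methoxy in place of chloro on an aromatic carbon, and the step that the two limits leave unreadable from compound 3 to compound 1 cannot be read because of the limit of > 10000 nM in this assay, at which 3 of the 3 values shown sit. Compound 2 and compound 3 share the same atoms joined differently; the difference between the two cores is not broken down here.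

Compound 4 `COc1ccccc1C1CCc2nc[nH]c2C1` has not been measured. It differs from compound 2 by methoxy in place of chloro on an aromatic carbon, the same kind of change as from compound 3 to compound 1, but here ortho rather than meta to the group of 9 heavy atoms. Since all three measured values sit at the limit, the step that the limit leaves unreadable from compound 2 to compound 4 for compound 4 is expected to stay near zero, and compound 4 is estimated at 15000 nM, most likely again reported only as a limit.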

Compound 4, half-maximal effective concentration: 3500 nM
Estimate against measurement, compound 4: 4.3-fold (0.63 log units) above; the measured number falls inside the stated range.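

In this assay, placing methoxy instead of chloro ortho to the group of 9 heavy atoms gives an at least 2.8-fold lower number from compound 2 to compound 4 (0.45 log units; beyond the scatter), so on this core the change means that less compound is needed. On these data alone, the value of compound 2, > 10000 nM, is a limit and not a number, so the true size of this step is unknown. The same change on the other core, from compound 3 to compound 1, cannot be read, so this result does not show that the effect carries from one core to the other: the limit of > 10000 nM in this assay, at which 3 of the 4 values shown sit.

The compounds shown leave open whether methoxy is unusual at this position. An amine, a carboxylic acid or a longer chain there might give a higher or a lower number.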